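From Dimethylamino to Ethoxy on a Short Side Chain

The source may hold more compounds than are shown below. What is called first, only, known or untested is meant among the compounds shown, and "the series" means these compounds.

Measured compounds:
compound 1 `CCCn1c(=O)n(CCC(N)=O)c(=O)c2[nH]cnc21`: 31500 nM
compound 2 `CCCn1c(=O)n(CCN(C)C)c(=O)c2[nH]cnc21`: 4300 nM

Both compounds share the same core and differ only in the group carried on the saturated chain two bonds from an aromatic nitrogen. In an assay on Cerebral cortex for binding affinity to adenosine receptor A1 (Cavia porcellus), read by radioligand binding (a lower number here means a stronger inhibitor, a higher number a weaker inhibitor), compound 1 gives 31500 nM and compound 2 gives 4300 nM. For the measured compounds named here, compound 2 therefore stands as the lower of the two numbers measured so far; the single measured step, a 7.3-fold lower number from compound 1 to compound 2 (0.86 log units; beyond the scatter), is the only guide to how this position behaves.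

Compound 3 `CCCn1c(=O)n(CCOCC)c(=O)c2[nH]cnc21` has not yet been measured. It differs from compound 2 by ethoxy in place of dimethylamino on a saturated chain carbon, two bonds along the chain from an aromatic nitrogen. Going by the values given here, the measured step bears on it only loosely: it shows that exchanging the group at this position can move the number beyond the scatter, but no measured pair exchanges an amine for an ether. With that single point of reference, the expected step of a 1.9-fold higher number from compound 2 to compound 3 (0.27 log units; within the scatter) is a modest rise in this assay, possibly no more than the scatter. Compound 3 is therefore estimated at 8000 nM, with a range from 2500 nM to 30000 nM.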

Compound 3, inhibition constant: 1900 nM
Compound 3: middle estimate off by 4.2-fold (0.62 log units), on the high side, and the stated range ends above it.
By their numbers in this assay, from the lowest: compound 3; then compound 2; then compound 1.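

In this assay, ethoxy in place of dimethylamino gives a 2.3-fold lower number from compound 2 to compound 3 (0.35 log units; beyond the scatter), so on this short side chain an amine is not required for the lowest number among the three compounds, and an ether does better. Dimethylamino and ethoxy have the same listed counts of heavy atoms, hydrogen-bond donors and hydrogen-bond acceptors, and neither carries a net charge, yet the number still moves beyond the usual scatter, so those counts alone do not fix the result at this position. Ethoxy in place of carbamoyl gives a 17-fold lower number from compound 1 to compound 3 (1.22 log units; beyond the scatter), the widest gap in the set, which shows that this one position can shift the number by a large step on the shared core, although nothing available here explains why the ethoxy compound gives the lowest number.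

Still open, as far as these compounds go, is how other groups on the same chain would behave, such as a hydroxyl, a methoxy, a carboxylic acid or a ring amine like morpholine. Also open, from the compounds shown here alone, is whether a longer chain carrying the ethoxy group would lower the number further or raise it again, since all three compounds share one chain length.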